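Adding Chlorine to the Other Aromatic Ring

The compounds below may be only part of what the source reports. "The series", "measured", "known", "first", "only" and "open" are said of these compounds alone.

Three measured compounds share one core. Compound 1 `COc1ccc(-c2nc(SCC(=O)c3sc(-c4ccccc4)nc3C)nc(N)c2C#N)cc1` gives 60.8% in a functional assay on U-87MG ATCC cells for antiproliferative activity against U-87 MG (Homo sapiens), read by MTT assay, with a stated time of 48 h, tested at 10 uM; a higher number here means a weaker effect of the compound at the concentration tested, a lower number a stronger effect. Compound 2 `Cc1nc(-c2ccccc2)sc1C(=O)CSc1nc(N)c(C#N)c(-c2ccc(Cl)cc2)n1` gives 58.8%. Compound 3 `Cc1nc(-c2ccccc2)sc1C(=O)CSc1nc(N)c(C#N)c(-c2ccccc2)n1` gives 93%, the highest of the three numbers; its steps from the others, a number 32.2 percentage points higher from compound 1 to compound 3 (beyond the scatter) and a number 34.2 percentage points higher from compound 2 to compound 3 (beyond the scatter), both lie beyond the scatter, so compound 3 shows the weakest effect of the three. Compound 4 `Cc1nc(-c2ccc(Cl)cc2)sc1C(=O)CSc1nc(N)c(C#N)c(-c2ccccc2)n1` differs from compound 3 by chloro in place of hydrogen on an aromatic carbon. The measured steps changed a different six-membered aromatic ring of carbon only; only a number 34.2 percentage points higher from compound 2 to compound 3 (beyond the scatter) involved chloro, and it ran the opposite way, lowering strongly when read backwards. A moderate fall in this assay is therefore expected, with wide uncertainty. Compound 4 is estimated at 75%, between 55% and 95%, an expected step of a number 18 percentage points lower from compound 3 to compound 4 (beyond the scatter).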

Compound 4, a percentage reported as activity, at one concentration (the size of the read-out at that concentration, not a potency): 67.9%
Estimate against measurement, compound 4: 7.1 percentage points above; the measured number falls inside the stated range.
By their numbers in this assay, from the lowest: compounds 2, 1 and 4 (each within the scatter of the next); then compound 3.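

Chloro on the phenyl ring attached to the other heteroaromatic ring, a ring the earlier steps left untouched, also strengthens the effect in this assay, giving a number 25.1 percentage points lower from compound 3 to compound 4 (beyond the scatter). The sensitivity to substitution is therefore not confined to the aromatic ring changed earlier, and compound 3, with neither ring substituted, now shows the weakest effect of the four. No available measurement explains this change. Still open, going by these compounds, is how an amine or a carboxylic acid would behave at this position, and whether chloro on both aromatic rings would strengthen the effect further.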